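Adding a 4-methoxybenzyl to the sulfur of compound 3

A few compounds are considered here, and "the series" means these few. Any claim that something is new, unique, unknown or untested is made for them only; others in the source may bear on it.

Of the compounds shown here, three sharing one core have been tested in a functional assay on L1210 cells (Mus musculus) for inhibition; a higher number here means a weaker inhibitor, a lower number a stronger inhibitor. Compound 1 `CCOC(=O)Nc1cc(N/N=C/c2ccccc2)c2[nH]c(SCc3ccccc3)nc2n1` gives 46000 nM. Compound 2 `CCOC(=O)Nc1cc2c(nc(S)n2/N=C/c2ccccc2)c(N)n1` gives 470 nM. For compound 3 `CCOC(=O)Nc1cc2c(nc(S)n2N)c(N)n1` the assay reports only a limit, > 30000 nM, so no exact number is known. Among the measured compounds shown here, the single measured step, an at least 63-fold higher number from compound 2 to compound 3 (1.80 log units; beyond the scatter), shows that stripping the core at its aromatic nitrogen costs a great deal of potency; its size is read against (the limit of > 30000 nM in this assay, at which 1 of the 3 values shown sits). Compound 4 `CCOC(=O)Nc1cc2c(nc(SCc3ccc(OC)cc3)n2N)c(N)n1` differs from compound 3 by 4-methoxybenzyl in place of hydrogen on a sulfur. For the measured compounds named here, no measured step touches that sulfur, so the step to compound 4 can only be judged loosely: compound 1, which also carries a benzyl-type group on its sulfur but differs elsewhere, is a weak inhibitor, and compound 3 itself sits at the limit. The change from compound 3 to compound 4 is therefore expected to move the number by only a modest amount, an at least 1.2-fold lower number from compound 3 to compound 4 (0.07 log units; that floor lies within the scatter), with the direction uncertain. Compound 4 is estimated at 25000 nM in this assay, within a range from 4000 nM to 150000 nM.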

Compound 4, half-maximal inhibitory concentration: 60 nM
Estimate against measurement, compound 4: 420-fold (2.62 log units) above; measured number outside the range, below it.
By their numbers in this assay, from the lowest: compound 4; then compound 2; then compound 1.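

Among the compounds shown here, until now no measured step touched this sulfur, and the first one to do so, an at least 500-fold lower number from compound 3 to compound 4 (2.69 log units; beyond the scatter), shows that in this assay this position strongly affects the read-out. The earlier step at the aromatic nitrogen left open whether compound 3 could regain potency only through a larger group at that nitrogen, but compound 4 keeps the same small nitrogen substituent and still reaches a low number, so a change on the sulfur alone is enough. Compound 3 has only a limit, > 30000 nM, so this step gives a floor and its full size stays unknown: the limit of > 30000 nM in this assay, at which 1 of the 4 values shown sits.

The compounds shown leave open how much of this change belongs to the aromatic ring and how much to the methoxy group, which a plain benzyl or a methyl on the same sulfur, with the rest of compound 4 kept, would help to separate. Also open, going by these compounds, is whether the group that compound 2 carries on its aromatic nitrogen would add to the effect of the 4-methoxybenzyl on the sulfur if both stood in one compound.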